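The source may report more compounds than this note shows. Statements on the series, on what has been measured and on what is new or still open speak of the compounds shown alone.

Of the compounds shown here, three have been measured in a functional assay on SMMC-7721 cells (Homo sapiens) for inhibition, read by MTT assay, with a stated time of 72 h, tested at 1 uM; a higher number here means a stronger effect of the compound at the concentration tested, a lower number a weaker effect. Compound 1 `Cc1cccc2ncnc(O/N=C(\C=C\c3ccccn3)/C=C/c3ccccc3OCc3ccc(Cl)cc3Cl)c12` gives 90.8%. Compound 2 `Clc1ccccc1COc1ccccc1/C=C/C(/C=C/c1ccccn1)=N/Oc1ncnc2ccccc12` gives 95.7%, the highest of the three numbers. Compound 3 `Fc1ccccc1COc1ccc(/C=C/C(/C=C/c2ccccn2)=N/Oc2ncnc3cc(Cl)ccc23)cc1` gives 81.1%. Compound 2 stands beyond the usual scatter above compound 3, while compound 1 lies within the scatter of compound 2, so no order can be read between compound 1 and compound 2.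

Compound 4 `Clc1ccc2c(O/N=C(\C=C\c3ccccn3)/C=C/c3ccccc3OCc3ccccc3Cl)ncnc2c1` has not yet been measured. It differs from compound 2 in one place: chloro in place of hydrogen on an aromatic carbon. Going by the values given here, no measured pair differs only in this way, so the size of the step has to be judged from the whole set. Compound 3 also carries a chloro on its core, yet it differs from compound 2 in other places as well, so its lower number is only a weak hint. The expected step is a number 5.7 percentage points lower from compound 2 to compound 4 (within the scatter), small and, if anything, a slight fall. Compound 4 is expected to give about 90% in this assay, with a likely range from 78% to 98%.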

Compound 4, a percentage reported as inhibition, at one concentration (the size of the read-out at that concentration, not a potency): 94.8%
Beside the measured number, compound 4's estimate is 4.8 percentage points below it; measured number inside the range.
By their numbers in this assay, from the lowest: compounds 3, 1, 4 and 2 (each within the scatter of the next, the first and the last beyond it).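

Adding a chloro to the core, which turns quinazolin-4-yl into 7-chloroquinazolin-4-yl, can now be read directly for the first time: in this assay the step is a number 0.9 percentage points lower from compound 2 to compound 4 (within the scatter). This aromatic carbon therefore accepts a chloro in this pair with no change that can be told from the usual scatter, at least at the single concentration tested. No measurement shown here gives a reason for this result.

On these data alone, whether an amine, a methoxy group or a bromo on the same carbon would give a similar reading remains open. Each number is the size of the effect at one concentration and not a potency. A real difference between compound 2 and compound 4 at lower concentrations also remains possible.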